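Replacing 4-methoxy-3-methylphenyl with 4-bromophenyl in compound 2

The compounds below may be only part of what the source reports. "The series", "measured", "known", "first", "only" and "open" are said of these compounds alone.

In a functional assay on MCF-A cells (Homo sapiens) for cytotoxicity (on this read-out higher numbers stand for weaker inhibition of growth and lower numbers for stronger inhibition of growth), compound 1 `COc1ccc(C2=C(c3ccc(SC)cc3)CC3CCCN3C2=O)cc1Br` gives 6000 nM. Going by the values given here, compound 2 `COc1ccc(C2=C(c3ccc(SC)cc3)CC3CCCN3C2=O)cc1C` gives 400 nM, the lower of the two numbers so far. Compound 3 `CSc1ccc(C2=C(c3ccc(Br)cc3)C(=O)N3CCCC3C2)cc1` carries 4-bromophenyl in place of 4-methoxy-3-methylphenyl on a double-bonded ring carbon. Among the compounds with values here, only one measured step bears on this change: a 15-fold lower number from compound 1 to compound 2 (1.18 log units; beyond the scatter), a large step for methyl in place of bromo on an aromatic carbon. Read backwards, it ties bromo to the higher number. Within the data shown here, no measured compound shows the 4-bromophenyl group itself, and the loss of the methoxy has not been measured alone, so a higher number of moderate size, smaller than that step, is expected in this assay. The expected step is a 6.3-fold higher number from compound 2 to compound 3 (0.80 log units; beyond the scatter). For compound 3 the estimated value is 2500 nM, with an expected range from 600 nM to 10000 nM.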

Compound 3, concentration for 50% growth inhibition: 8000 nM
Estimate against measurement, compound 3: 3.2-fold (0.51 log units) below, and the stated range covers the measured number.
By their numbers in this assay, from the lowest: compound 2; then compounds 1 and 3 (each within the scatter of the next).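

In this assay, the swap at this double-bonded ring carbon is a large change (a 20-fold higher number from compound 2 to compound 3 (1.30 log units; beyond the scatter)), so 4-bromophenyl does not stand in for 4-methoxy-3-methylphenyl here. The two bromo-bearing groups cannot be told apart (a 1.3-fold higher number from compound 1 to compound 3 (0.12 log units; within the scatter)), which leaves compound 2, with its 4-methoxy-3-methylphenyl group, alone at the lower number among the three compounds, and shows that a 3-bromo-4-methoxyphenyl group keeps no advantage over 4-bromophenyl despite its methoxy. Nothing at hand accounts for these differences.

The compounds shown leave open how much of the lower number of compound 2 goes with its methyl and how much with its methoxy, as none carries one of these groups without the other. They also leave open how a phenyl ring bearing an amine or a carboxylic acid would read at this carbon.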